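Compound 3: methyl in place of methoxy

The source may hold more compounds than are shown below. What is called first, only, known or untested is meant among the compounds shown, and "the series" means these compounds.

Measured so far:
compound 1 `Cc1ccc2[nH]c(-c3cn(-c4ccccc4)nc3-c3ccc(Cl)cc3)nc2c1` gives 5360 nM
compound 2 `COc1ccc(-c2nn(-c3ccccc3)cc2-c2nc3cc(OC)ccc3[nH]2)cc1` gives 1140 nM

In a functional assay on HeLa cells (Homo sapiens) for antiproliferative activity, read by MTT assay, with a stated time of 48 h (a lower number here means a stronger inhibitor, a higher number a weaker inhibitor), compound 2 holds the lower of the two numbers (1140 nM), and the gap up to compound 1 lies beyond the usual scatter.

Compound 3 `COc1ccc(-c2nn(-c3ccccc3)cc2-c2nc3cc(C)ccc3[nH]2)cc1` follows from compound 2 with methyl in place of methoxy on an aromatic carbon and no other change. Within the data shown here, no pair of measured compounds isolates this change, so there is no direct evidence for the size of the step. In this assay a modest rise in the number is expected, close to the edge of the scatter, and a result with no real change would not be surprising. The expectation leans upward because compound 1 at 5360 nM is the only other measured point and sits higher. The estimated move is a 1.7-fold higher number from compound 2 to compound 3 (0.22 log units; within the scatter) and remains tentative. For compound 3 the expected value is 1900 nM within an estimated range of 700 nM to 5000 nM.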

Compound 3, half-maximal inhibitory concentration: 3290 nM
For compound 3 the middle estimate is 1.7-fold (0.24 log units) below the measured one; low and high end bracket the measured number.
By their numbers in this assay, from the lowest: compound 2; then compounds 3 and 1 (each within the scatter of the next).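

In this assay, among these compounds, the exchange on the fused system gives a 2.9-fold higher number from compound 2 to compound 3 (0.46 log units; beyond the scatter) and is the first single change read at this position: on this aromatic carbon, methoxy and methyl are separated, and methoxy is the group with the lower number. Compound 3 also ties compound 1 to the series by one change, as chloro replaced by methoxy on an aromatic carbon gives a 1.6-fold lower number from compound 1 to compound 3 (0.21 log units; within the scatter) and therefore does not separate those two groups while methyl stays on the fused system. The evidence at hand offers no measured property or other data that would account for either step.

As far as these compounds go, the comparison at this position covers only methoxy and methyl, so it remains open whether a hydroxyl, an amine or a longer chain such as ethoxy on the same carbon would bring the number closer to that of compound 2 or move it further away. Also open is whether the exchange of methoxy for methyl keeps its size when chloro stands in place of the other methoxy, since the compounds shown give that exchange with only one partner group.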